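Thiophene attachment point on the methylthio-bearing core

The source may hold more compounds than are shown below. What is called first, only, known or untested is meant among the compounds shown, and "the series" means these compounds.

The series shares one core. Compound 1 `Cc1ncnc2c1c(-c1ccsc1)cn2[C@@H]1O[C@H](CO)[C@@H](O)[C@H]1O` gives 460 nM in a functional assay on HCT-116 cells (Homo sapiens), read by MTT assay, with a stated time of 72 h; on this read-out lower numbers stand for stronger inhibition and higher numbers for weaker inhibition. Compound 2 `CN(C)c1ncnc2c1c(-c1ccsc1)cn2[C@@H]1O[C@H](CO)[C@@H](O)[C@H]1O` returns only the assay limit in this assay, > 20000 nM. Compound 3 `CSc1ncnc2c1c(-c1cccs1)cn2[C@@H]1O[C@H](CO)[C@@H](O)[C@H]1O` likewise returns only the assay limit, > 20000 nM. Two of the three values recorded sit at the limit of > 20000 nM in this assay, at which 2 of the 3 values shown sit. Going by the values given here, the single measured step, an at least 43-fold higher number from compound 1 to compound 2 (1.63 log units; beyond the scatter), concerns the group on the other aromatic carbon and not the thiophene. Compound 4 `CSc1ncnc2c1c(-c1ccsc1)cn2[C@@H]1O[C@H](CO)[C@@H](O)[C@H]1O` differs from compound 3 by thiophen-3-yl in place of thiophen-2-yl on an aromatic carbon. Among the compounds with values here, no measured pair bears on this change, so neither a direction nor a size beyond the scatter can be drawn from the steps. Compound 4 is therefore expected near 15000 nM, within 2000 nM to 60000 nM. The expected step is an at least 1.3-fold lower number from compound 3 to compound 4 (0.12 log units; that floor lies within the scatter).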

Compound 4, half-maximal inhibitory concentration: > 20000 nM
Compound 4 gave a limit, no number (the forecaster's own chance of this, stated with the estimate: 55%); middle value at least 1.3-fold (0.12 log units) away from the limit.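

Compound 4 in this assay returns a limit and not a number: the limit of > 20000 nM in this assay, at which 3 of the 4 values shown sit. With thiophen-3-yl held, methylsulfanyl in place of methyl gives an at least 43-fold higher number from compound 1 to compound 4 (1.63 log units; beyond the scatter), so on this aromatic carbon methylsulfanyl, like dimethylamino, separates from methyl. The steps from compound 2 and compound 3 to compound 4 join two limits and cannot be read, so thiophen-3-yl and thiophen-2-yl are not told apart on the methylsulfanyl-bearing core.

As far as these compounds go, whether the thiophene attachment point matters with methyl on that carbon stays open. So does the standing of a primary amine or an ethyl chain there.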